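From 4-hydroxyphenyl to 3,4-dimethoxyphenyl on a shared core

The compounds below may be only part of what the source reports. "The series", "measured", "known", "first", "only" and "open" are said of these compounds alone.

Compound 1 `COc1ccc(-c2ccc(-c3ccc(-c4nc5cc(C)ccc5[nH]4)cc3)cc2)cc1OC`: 3510 nM
Compound 2 `Oc1ccc(-c2ccc(-c3ccc(-c4nc5c(O)cccc5[nH]4)cc3)cc2)cc1`: 2410 nM

The two measured compounds were tested in a functional assay on SiHa cells (Homo sapiens) for inhibition, read by sulforhodamine B assay; on this read-out higher numbers stand for weaker inhibition of growth and lower numbers for stronger inhibition of growth. There, compound 2 gives 2410 nM, which lies within the usual scatter of the value for compound 1, 3510 nM. On these numbers, neither compound can be ranked ahead of the other.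

The next compound to be tested is compound 3 `COc1ccc(-c2ccc(-c3ccc(-c4nc5c(O)cccc5[nH]4)cc3)cc2)cc1OC`. It keeps the rest of compound 2 and changes one group: 3,4-dimethoxyphenyl in place of 4-hydroxyphenyl on an aromatic carbon. 3,4-dimethoxyphenyl stands in place of 4-hydroxyphenyl, on an aromatic carbon para to a large group.

Going by the values given here, no measured pair isolates this change, so any expectation rests on thin evidence. Compound 1 already carries 3,4-dimethoxyphenyl, and its value of 3510 nM sits within the scatter of compound 2. A large shift in this assay is therefore not expected. The expected 1.2-fold higher number from compound 2 to compound 3 (0.07 log units; within the scatter) stays within the scatter, with no firm direction. For compound 3 the estimated value is 2800 nM, with an expected range from 1200 nM to 6500 nM.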

Compound 3, concentration for 50% growth inhibition: 1110 nM
Compound 3: middle estimate off by 2.5-fold (0.40 log units), on the high side, and the stated range ends above it.
By their numbers in this assay, from the lowest: compound 3; then compounds 2 and 1 (each within the scatter of the next).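

In this assay, 3,4-dimethoxyphenyl in place of 4-hydroxyphenyl, on an aromatic carbon para to a large group, gives a 2.2-fold lower number from compound 2 to compound 3 (0.34 log units; beyond the scatter). Going by these compounds alone, this is the first change at this position that can be read on its own, and although modest, it shows that the position affects the read-out. With 3,4-dimethoxyphenyl held constant, 4-hydroxy-1H-benzimidazol-2-yl in place of 5-methyl-1H-benzimidazol-2-yl gives a 3.2-fold lower number from compound 1 to compound 3 (0.50 log units; beyond the scatter), so compound 3, which pairs the 3,4-dimethoxyphenyl group of compound 1 with the 4-hydroxy-1H-benzimidazol-2-yl group of compound 2, stands beyond the scatter of both, while those two could not be ranked. Nothing measured here accounts for either step.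

The compounds shown leave open whether both methoxy groups contribute, or whether a single methoxy, a 4-aminophenyl group or a 4-carboxyphenyl group at the same position would serve equally well. Within the data shown here, they also leave open whether the step from 4-hydroxyphenyl to 3,4-dimethoxyphenyl would carry over to the 5-methyl-1H-benzimidazol-2-yl series, since only one such pair can be read.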